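A few compounds are considered here, and "the series" means these few. Any claim that something is new, unique, unknown or untested is made for them only; others in the source may bear on it.

Measured so far:
- Compound 1, `O/N=C(\CCN1CCN(c2ccccn2)CC1)c1ccccc1Cl`: 74% in a functional assay on HEK293 cells with D(4) dopamine receptor (Homo sapiens) as the target, read by FLIPR; on this read-out higher numbers stand for larger maximal responses and lower numbers for smaller maximal responses
- Compound 2, `O/N=C(\CCN1CCN(c2ccccn2)CC1)c1cccc(F)c1`: 72% in this assay

Compound 2 holds the lower of the two numbers, with compound 1 nearest; the step of a number 2 percentage points lower from compound 1 to compound 2 (within the scatter) lies within the scatter. Compound 3, `O/N=C(\CCN1CCN(c2ccccn2)CC1)c1cccc(Cl)c1`, is not yet measured. It differs from compound 2 by chloro in place of fluoro on an aromatic carbon. Among the compounds with values here, the only step in hand, a number 2 percentage points lower from compound 1 to compound 2 (within the scatter), swapped one halogen-bearing phenyl for another without a change beyond the scatter, and the move from compound 2 to compound 3 is of the same kind. Compound 3 is therefore expected to show a number 1 percentage points higher from compound 2 to compound 3 (within the scatter), with an estimate of 73% (range 60% to 86%).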

Compound 3, largest response reached (reported as efficacy), in percent of the reference or control that the assay uses: 73%
Estimate against measurement, compound 3: no gap at the digits printed, and the stated range covers the measured number.
By their numbers in this assay, from the lowest: compounds 2, 3 and 1 (each within the scatter of the next).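

In this assay, chloro in place of fluoro on this aromatic carbon, meta to a large group, gives a number 1 percentage points higher from compound 2 to compound 3 (within the scatter) and so separates the two halogens no further than the earlier halogen-bearing pair. With chloro kept, 3-chlorophenyl in place of 2-chlorophenyl gives a number 1 percentage points lower from compound 1 to compound 3 (within the scatter) as the one listed step that compares these two placements. Nothing available accounts for these small steps.

As far as these compounds go, whether an amine or a carboxylic acid at this place would keep the response in this range remains open. So does the effect of a longer chain in the shared core.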